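The compounds below may be only part of what the source reports. "The series", "measured", "known", "first", "only" and "open" are said of these compounds alone.

Compound 2 `NCc1cc(C(=O)O)ccc1CN(Cc1nc2ccccc2[nH]1)C1CCCc2cccnc21` gives the higher of the two numbers seen so far in a functional assay on CEM-CCRF cells for antagonist activity at C-X-C chemokine receptor type 4 (Homo sapiens), read by calcium flux; on this read-out lower numbers stand for stronger inhibition and higher numbers for weaker inhibition: compound 2 shows 126 nM, while compound 1 `NCc1ccccc1CN(Cc1nc2ccccc2[nH]1)C1CCCc2cccnc21` shows 28 nM, with a 4.5-fold higher number from compound 1 to compound 2 (0.65 log units; beyond the scatter) between them. Compound 3 `NCc1ccncc1CN(Cc1nc2ccccc2[nH]1)C1CCCc2cccnc21` carries a group of 8 heavy atoms (6 carbon, 2 nitrogen; one six-membered aromatic ring with 1 hetero atom) in place of a group of 11 heavy atoms (8 carbon, 1 nitrogen, 2 oxygen; one six-membered aromatic ring of carbon only), on a saturated chain carbon bound to an amine nitrogen. Among the compounds with values here, the only measured step that bears on this change, the one from compound 1 to compound 2, shows that the carboxy group raised the number; its removal in compound 3 is expected to take much of that back, while the new ring nitrogen is untested. The estimated step is a 3.2-fold lower number from compound 2 to compound 3 (0.50 log units; beyond the scatter). Compound 3 is therefore expected to give 40 nM, with a range from 12 nM to 130 nM.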

Compound 3, half-maximal inhibitory concentration: 160 nM
The estimate for compound 3 lay 4.0-fold (0.60 log units) below the measured number; measured number above the stated range.
By their numbers in this assay, from the lowest: compound 1; then compounds 2 and 3 (each within the scatter of the next).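

In this assay, swapping the carbon-only ring for the ring with 1 hetero atom gives a 5.7-fold higher number from compound 1 to compound 3 (0.76 log units; beyond the scatter), so the number can rise at this place without any carboxy group. The two altered rings stand level, with a 1.3-fold higher number from compound 2 to compound 3 (0.10 log units; within the scatter), so two different changes to the ring of compound 1 end at much the same number. Nothing measured here explains this result.

Still open, on these data alone, is whether a smaller group on the carbon-only ring, such as fluorine or methoxy, would keep the number near that of compound 1.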